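The source may hold more compounds than are shown below. What is called first, only, known or untested is meant among the compounds shown, and "the series" means these compounds.

Compound 1 `O=[N+]([O-])c1ccc(-c2nnc(SCCCN3CCN(c4nc5ccccc5o4)CC3)o2)cc1` gives 67200 nM
Compound 2 `Fc1ccc(-c2nnc(SCCCN3CCN(c4nc5ccccc5o4)CC3)o2)cc1` gives 83800 nM

Among the compounds with values here, in a functional assay on HepG2 cells (Homo sapiens) for inhibition, read by MTT assay, with a stated time of 72 h (on this read-out higher numbers stand for weaker inhibition and lower numbers for stronger inhibition), compound 2 at 83800 nM stands level with compound 1, the only other compound measured so far, and the gap between the two lies within the scatter. Compound 3 `Oc1ccc(-c2nnc(SCCCN3CCN(c4nc5ccccc5o4)CC3)o2)cc1` has not yet been measured and departs from compound 2 in one place. The change is hydroxy in place of fluoro on an aromatic carbon and it turns 4-fluorophenyl into 4-hydroxyphenyl, with hydroxy in place of fluoro on an aromatic carbon, para to a large group. Within the data shown here, no measured compound carries the hydroxy group, so the data give no direct reading of this swap. The nearest evidence is a single step that also replaces a group on an aromatic carbon, fluoro in place of nitro. Given the small size of that step a 1.2-fold higher number from compound 1 to compound 2 (0.10 log units; within the scatter) no change beyond the scatter is expected in this assay and neither direction is favoured. The estimated step is a 1.2-fold lower number from compound 2 to compound 3 (0.08 log units; within the scatter) and it is expected to stay within the scatter. For compound 3 the estimated value is 70000 nM with an expected range from 35000 nM to 130000 nM on repeated measurement.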

Compound 3, half-maximal inhibitory concentration: 502000 nM
Estimate against measurement, compound 3: 7.2-fold (0.86 log units) below, and the stated range ends below it.
By their numbers in this assay, from the lowest: compounds 1 and 2 (each within the scatter of the next); then compound 3.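

In this assay, the place on the aromatic ring that had shown no change beyond the scatter on going from nitro to fluoro proves sensitive to what it carries: hydroxy in place of fluoro gives a 6.0-fold higher number from compound 2 to compound 3 (0.78 log units; beyond the scatter), and hydroxy in place of nitro gives a 7.5-fold higher number from compound 1 to compound 3 (0.87 log units; beyond the scatter). Both steps are modest, but both point to weaker inhibition, so among these three compounds hydroxy stands apart from the two groups that lie within the scatter of each other. Hydroxy brings a hydrogen-bond donor and a hydrogen-bond acceptor that the leaving fluoro lacks, but nothing measured here links that difference to the result.

The compounds shown leave open whether the rise follows the hydroxy hydrogen or the oxygen itself, a question on which a methoxy group at this place would bear. They also do not tell whether an amine or a carboxylic acid at the same place would behave like hydroxy, or like nitro and fluoro.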